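One Extra Chain Carbon on a Weak Inhibitor

The source may report more compounds than this note shows. Statements on the series, on what has been measured and on what is new or still open speak of the compounds shown alone.

In a functional assay on Hep 3B2 cells (Homo sapiens) for inhibition, read by MTT assay, with a stated time of 72 h (a lower number here means a stronger inhibitor, a higher number a weaker inhibitor), compound 1 (`Nc1ncnc2c1c(-c1cnc3[nH]ccc3c1)nn2CCCCCC(=O)NO`) gives > 50000 nM as its reading. That reading is a limit of the assay and not a number. Among the compounds with values here, compound 2 (`Nc1nc2cc(-c3nn(CCCCCCCCCC(=O)NO)c4ncnc(N)c34)ccc2o1`) gives 28800 nM in this assay and is the only true number available. Compound 3 (`Nc1ncnc2c1c(-c1cnc3[nH]ccc3c1)nn2CCCCCCC(=O)NO`) carries (hydroxycarbamoyl)methyl in place of hydroxycarbamoyl on a saturated chain carbon, five bonds along the chain from an aromatic nitrogen. Within the data shown here, no measured step guides this change, so only a modest gain in strength is expected, an estimated at least 1.6-fold lower number from compound 1 to compound 3 (0.22 log units; that floor lies within the scatter) in size. Compound 3 is expected at 30000 nM (estimated range 10000 nM to 70000 nM) in this assay as well.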

Compound 3, half-maximal inhibitory concentration: 26300 nM
Compound 3: middle estimate off by 1.1-fold (0.06 log units), on the high side, within the range that was stated.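

Within the data shown here, on this core, (hydroxycarbamoyl)methyl in place of hydroxycarbamoyl, on a saturated chain carbon, gives the first true number for the series in this assay, and the change reads as an at least 1.9-fold lower number from compound 1 to compound 3 (0.27 log units; that floor lies within the scatter). This step is only a floor because compound 1 has a limit and not a number: the limit of > 50000 nM in this assay, at which 1 of the 3 values shown sits. On these data alone, the true size of the change therefore stays unknown, and a real gain in strength is not established.

Still open, as far as these compounds go, is how a longer chain on this same core would read. A carboxylic acid in place of the hydroxycarbamoyl end is also untested among the compounds shown.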